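Moving the chlorine from 4-chlorophenyl to 3-chlorophenyl

The compounds below may be only part of what the source reports. "The series", "measured", "known", "first", "only" and "open" are said of these compounds alone.

In a functional assay on ECa-109 cells (Homo sapiens) for cytotoxicity, read by MTT assay, with a stated time of 72 h (on this read-out lower numbers stand for stronger inhibition and higher numbers for weaker inhibition), compound 1 `CC(C)=C1C(=O)N(c2ccc(Cl)cc2)N(c2ccc(Cl)cc2)C1=O` gives 42100 nM and compound 2 `CCC(C)=C1C(=O)N(c2ccc(Cl)cc2)N(c2ccc(Cl)cc2)C1=O` gives 41100 nM. Compound 3 `O=C1C(=Cc2ccc(Cl)cc2)C(=O)N(c2ccc(Cl)cc2)N1c1ccc(Cl)cc1` gives 17300 nM, the lowest of the three numbers and beyond the scatter from both others. The unmeasured compound 4 `O=C1C(=Cc2cccc(Cl)c2)C(=O)N(c2ccc(Cl)cc2)N1c1ccc(Cl)cc1` has 3-chlorophenyl in place of 4-chlorophenyl on the double-bonded chain carbon: 3-chlorophenyl in place of 4-chlorophenyl on a double-bonded chain carbon bound to a double-bonded ring carbon. Among the compounds with values here, the only measured step between compounds differing in one place, a 1.0-fold lower number from compound 1 to compound 2 (0.01 log units; within the scatter), lies within the scatter, but it involves a different change. Within the data shown here, no measured step moves the chlorine, so the data give no direct size for this one. The expected step is a 1.2-fold higher number from compound 3 to compound 4 (0.06 log units; within the scatter), with no shift beyond the scatter expected. For compound 4 the estimated value is 20000 nM, with an expected range of 9000 nM to 42000 nM.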

Compound 4, half-maximal inhibitory concentration: 22600 nM
Estimate against measurement, compound 4: 1.1-fold (0.05 log units) below; the range from low to high includes it.
By their numbers in this assay, from the lowest: compounds 3, 4, 2 and 1 (each within the scatter of the next, the first and the last beyond it).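

Moving the chlorine gives the first measured step for a change on the phenyl group at this place, on a double-bonded chain carbon bound to a double-bonded ring carbon. In this assay, 3-chlorophenyl in place of 4-chlorophenyl gives a 1.3-fold higher number from compound 3 to compound 4 (0.12 log units; within the scatter), so the two chlorophenyl groups cannot be told apart in this assay. No measurement at hand accounts for this result.

From the compounds shown here alone, whether the chlorine itself contributes at this place remains open. Also open, going by these compounds, is whether a methoxy group or a carboxylic acid on this phenyl group would give a step beyond the scatter.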